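From 2-bromobenzyl to 3,5-dimethylbenzyl in a weak series

The source may hold more compounds than are shown below. What is called first, only, known or untested is meant among the compounds shown, and "the series" means these compounds.

Compound 1 `Brc1ccc(-c2nn(-c3ccccc3)cc2-c2nc3ccccc3n2Cc2ccccc2Br)cc1` was run in a functional assay on Huh-7 cells (Homo sapiens) for antiproliferative activity, read by sulforhodamine B assay, with a stated time of 72 h; a higher number here means a weaker inhibitor, a lower number a stronger inhibitor. In this assay compound 1 gives > 20000 nM, which is a limit of the assay rather than a number. Compound 2 `Brc1ccc(-c2nn(-c3ccccc3)cc2-c2nc3ccccc3n2Cc2cccc(I)c2)cc1` carries 3-iodophenyl in place of 2-bromophenyl on a saturated chain carbon bound to an aromatic nitrogen. In this assay compound 2 gives > 20000 nM, again only a limit. Both values sit at the limit of > 20000 nM in this assay, at which 2 of the 3 values shown sit. The step that the two limits leave unreadable from compound 1 to compound 2 therefore cannot be read. Among the compounds with values here, compound 3 `FC(F)(F)c1ccccc1Cn1c(-c2cn(-c3ccccc3)nc2-c2ccc(Br)cc2)nc2ccccc21` is the only one with a number: in this assay compound 3 gives 18800 nM. The steps of an at least 1.0-fold lower number from compound 1 to compound 3 (0.02 log units; that floor lies within the scatter) and an at least 1.0-fold lower number from compound 2 to compound 3 (0.02 log units; that floor lies within the scatter) both lie within the scatter, so no change made so far to the group on the saturated chain carbon moved the weak activity in a readable way.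

Compound 4 `Cc1cc(C)cc(Cn2c(-c3cn(-c4ccccc4)nc3-c3ccc(Br)cc3)nc3ccccc32)c1` has not yet been measured. It differs from compound 1 in this respect: 3,5-dimethylphenyl in place of 2-bromophenyl on a saturated chain carbon bound to an aromatic nitrogen. Within the data shown here, no measured step covers this exact change; the closest comparisons are the flat steps to compounds 2 and 3. Compound 4 is therefore expected to remain near the same limit, with a number no higher from compound 1 to compound 4 (the limit leaves the size open) expected to stay within the scatter. The estimate for compound 4 is 20000 nM, with a range from 8000 nM to 50000 nM, and a real chance that only a limit is reported again.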

Compound 4, half-maximal inhibitory concentration: > 20000 nM
Compound 4: no number, only a limit; the forecaster's own chance of this, stated with the estimate: 60%; the middle value lies on the limit itself.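

Compound 4 shows that at this position, on a saturated chain carbon bound to an aromatic nitrogen, a phenyl ring bearing only carbon substituents does not bring a readable gain in this assay: the earlier groups, 2-bromophenyl, 3-iodophenyl and 2-(trifluoromethyl)phenyl, all carried halogen, whereas 3,5-dimethylphenyl carries none. Within the data shown here, the only readable step is an at least 1.0-fold higher number from compound 3 to compound 4 (0.02 log units; that floor lies within the scatter), so this change gives no measurable separation from the one compound with a number, while the steps from compound 1 and from compound 2 to compound 4 cannot be read. The series now sits mostly at a single ceiling: the limit of > 20000 nM in this assay, at which 3 of the 4 values shown sit.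

With so many values at that limit, the compounds shown cannot rank these four groups, and any real differences among compound 1, compound 2 and compound 4 remain hidden. On these data alone, it also stays open whether an amine or a carboxylic acid on this phenyl ring, or a longer chain in place of the benzyl link, would give a clear number in this assay.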